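The source may report more compounds than this note shows. Statements on the series, on what has been measured and on what is new or still open speak of the compounds shown alone.

Compound 2 `COc1ccc(-c2csc(NC(=O)COc3ccc(C(=O)c4ccc(F)cc4)cc3C)n2)cc1` carries a fluoro on the aryl ketone, and in a functional assay on DLA cells (Mus musculus) for cytotoxicity, read by trypan blue exclusion, with a stated time of 48 h (a higher number here means a weaker inhibitor, a lower number a stronger inhibitor), compound 2 gives 5000 nM. Compound 1 `COc1ccc(-c2csc(NC(=O)COc3ccc(C(=O)c4ccc(C)cc4)cc3C)n2)cc1` differs only by methyl in place of fluoro on an aromatic carbon, and this change made a 3.2-fold higher number from compound 2 to compound 1 (0.51 log units; beyond the scatter), so that compound 1 gives 16000 nM. Compound 3 `Cc1cc(C(=O)c2ccccc2F)ccc1OCC(=O)Nc1nc(-c2ccccc2)cs1` rests on another core; the difference between the cores of compound 3 and compound 2 is not broken down here. In this assay compound 3 gives 13700 nM, within the scatter of compound 1 and beyond the scatter from compound 2. Compound 4 `Cc1cc(C(=O)c2ccccc2C)ccc1OCC(=O)Nc1nc(-c2ccccc2)cs1` is not yet measured and differs from compound 3 by methyl in place of fluoro on an aromatic carbon. This is the same kind of change as that from compound 2 to compound 1, but not the same: there the place was para to a large group, here it is ortho to a large group. The expected step of a 2.2-fold higher number from compound 3 to compound 4 (0.34 log units; beyond the scatter) rests on the measured 3.2-fold higher number from compound 2 to compound 1 (0.51 log units; beyond the scatter), taken somewhat smaller since the place differs. Compound 4 is therefore expected to give about 30000 nM, with a likely range from 12000 nM to 80000 nM.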

Compound 4, half-maximal inhibitory concentration: 22200 nM
The estimate for compound 4 lay 1.4-fold (0.13 log units) above the measured number; low and high end bracket the measured number.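

In this assay, the change from 2-fluorophenyl to 2-methylphenyl on the core of compound 3 reads as a 1.6-fold higher number from compound 3 to compound 4 (0.21 log units; within the scatter), so on this core the swap cannot be told apart from repeat measurement. Set beside the earlier step on the other core, the two steps cannot be told apart either: the same change on two cores in this assay, a 3.2-fold higher number (0.51 log units; beyond the scatter) from compound 2 to compound 1 and a 1.6-fold higher number (0.21 log units; within the scatter) from compound 3 to compound 4, 2.0-fold (0.30 log units) apart, within the scatter of two such steps

This does not show that the change carries over with the same size, since only two pairs are shown and the two pairs differ in both core and place on the ring, the second being ortho to a large group, so the effect of core cannot be separated from that of place.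

The compounds shown leave open how the same swap would read on the core of compound 3 at the place it occupies in compound 2 and compound 1. Also open, on these data alone, is how a chloro, a methoxy, an amine or a carboxylic acid would read on the aryl ketone of either core.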